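Efficacy Notes: Removing the Propenyl Ether From Compound 1

The compounds below may be only part of what the source reports. "The series", "measured", "known", "first", "only" and "open" are said of these compounds alone.

Measured so far:
compound 1 `C/C=C\Oc1cncc(N2CCCNCC2)c1`: 45%
compound 2 `C=COc1cc(N2CCCNCC2)cnc1Br`: 80%

In an assay on HEK293 cells with Neuronal acetylcholine receptor; alpha4/beta2 (Homo sapiens) as the target, read by FLIPR and calcium flux (a lower number here means a smaller maximal response, a higher number a larger maximal response), compound 1 gives 45%, the lower of the two numbers, while compound 2 gives 80%, a value above it by more than the scatter. Compound 3 `Oc1cncc(N2CCCNCC2)c1` differs from compound 1 in one place: hydrogen in place of prop-1-en-1-yl on an oxygen on an aromatic ring. Among the measured compounds shown here, no measured pair shows a comparable change, so the direction is open. The step from compound 1 to compound 3 is expected to be a number 5 percentage points higher from compound 1 to compound 3 (within the scatter), modest and not clearly beyond the scatter. Compound 3 is estimated at 50% in this assay, with a range from 20% to 85%.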

Compound 3, largest response reached (reported as efficacy), in percent of the reference or control that the assay uses: 120%
Compound 3: the middle estimate sits 70 percentage points below what was measured, outside the stated range (above it).
By their numbers in this assay, from the lowest: compound 1; then compound 2; then compound 3.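

Among the compounds shown here, on the oxygen on an aromatic ring, replacing prop-1-en-1-yl with hydrogen gives the first single-place step: a number 75 percentage points higher from compound 1 to compound 3 (beyond the scatter) in this assay. The maximal response at this position therefore depends strongly on what the oxygen carries. Nothing available explains the size of this step.

On these data alone, it remains open whether a methyl or ethyl group on this oxygen would give a response nearer compound 1 or compound 3. Also open, as far as these compounds go, is how an amine in place of the oxygen would behave.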